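Ring enlargement on the sulfonamide of a nicotinic ligand

A few compounds are considered here, and "the series" means these few. Any claim that something is new, unique, unknown or untested is made for them only; others in the source may bear on it.

Measured so far:
Compound 1 `N#Cc1ccc2c(c1)C1CNCC2C1`: 0.5 nM
Compound 2 `O=S(=O)(c1ccc2c(c1)C1CNCC2C1)N1CC1`: 2 nM

Compound 1, bearing a nitrile on its aromatic ring, gives 0.5 nM in an assay on HEK293 cells for binding affinity to Neuronal acetylcholine receptor; alpha4/beta2 (Homo sapiens); on this read-out higher numbers stand for weaker inhibition and lower numbers for stronger inhibition. Within the data shown here, compound 2 carries an aziridinylsulfonyl group at the same aromatic carbon instead and gives 2 nM in this assay, the higher of the two numbers; the only step measured, a 4.0-fold higher number from compound 1 to compound 2 (0.60 log units; beyond the scatter), separates them.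

Compound 3 `O=S(=O)(c1ccc2c(c1)C1CNCC2C1)N1CCCC1` differs from compound 2 by pyrrolidin-1-yl in place of aziridin-1-yl on a sulfonyl sulfur. Among the measured compounds shown here, no measured pair touches this exchange of one saturated nitrogen ring for another; the single step, a 4.0-fold higher number from compound 1 to compound 2 (0.60 log units; beyond the scatter), only shows that replacing the nitrile by a sulfonamide costs modestly. Compound 3 is therefore expected to stay near compound 2, with a small upward drift, an estimated 1.5-fold higher number from compound 2 to compound 3 (0.18 log units; within the scatter). The estimate for compound 3 in this assay is 3 nM, within 1 nM to 10 nM.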

Compound 3, inhibition constant: 3.1 nM
The estimate for compound 3 lay 1.0-fold (0.01 log units) below the measured number; low and high end bracket the measured number.
By their numbers in this assay, from the lowest: compound 1; then compounds 2 and 3 (each within the scatter of the next).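

In this assay, putting pyrrolidin-1-yl in place of aziridin-1-yl on a sulfonyl sulfur gives a 1.6-fold higher number from compound 2 to compound 3 (0.19 log units; within the scatter), so the two sulfonamides cannot be told apart on this read-out. The earlier compounds shown here showed only what happened when the nitrile gave way to the aziridinylsulfonyl group; this pair shows that, between these two saturated nitrogen rings, the larger one enters on the sulfonyl sulfur without a step beyond the scatter. No evidence is available on what lies behind this result.

As far as these compounds go, whether the same holds for a piperidine or morpholine ring, or for an open-chain diethylamino group on the sulfonyl sulfur, remains open. Also open, from the compounds shown here alone, is how a simple unsubstituted sulfonamide or a carboxylic acid on the same aromatic carbon would compare with the nitrile of compound 1.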